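The source may hold more compounds than are shown below. What is called first, only, known or untested is meant among the compounds shown, and "the series" means these compounds.

Compound 1 `CNC(=O)c1ccc(CN(C)C(=O)c2cc(Cl)c(O)cc2O)cc1` gives 34800 nM in a functional assay on NCI-H1975 cells (Homo sapiens) for antiproliferative activity, with a stated time of 72 h (a higher number here means a weaker inhibitor of growth, a lower number a stronger inhibitor of growth), the highest of the two numbers shown, while compound 2 `CNC(=O)c1ccc(CN(C)C(=O)c2cc(C(C)C)c(O)cc2O)cc1` gives 860 nM in this assay. Within the data shown here, the one change with a measured step, a 40-fold lower number from compound 1 to compound 2 (1.61 log units; beyond the scatter), concerns a different position and does not bear on the change to compound 3 `CN(Cc1ccccc1)C(=O)c1cc(Cl)c(O)cc1O`, which shows (hydrogen in place of methylcarbamoyl on an aromatic carbon). Among the measured compounds shown here, with no measured step touching this group, no size beyond the scatter can be expected, so the step of a 1.4-fold higher number from compound 1 to compound 3 (0.16 log units; within the scatter) is estimated as a small one. Compound 3 is therefore expected to give about 50000 nM, within a range of 15000 nM to 160000 nM.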

Compound 3, concentration for 50% growth inhibition: 35500 nM
Estimate against measurement, compound 3: 1.4-fold (0.15 log units) above; low and high end bracket the measured number.
By their numbers in this assay, from the lowest: compound 2; then compounds 1 and 3 (each within the scatter of the next).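

With chloro on the shared core, hydrogen in place of methylcarbamoyl, para to a large group, gives a step that lies within the scatter in this assay (a 1.0-fold higher number from compound 1 to compound 3 (0.01 log units; within the scatter)). At this position, and at this weak level of growth inhibition, the two groups cannot be told apart. No evidence is available that bears on this result. From the compounds shown here alone, whether the same holds with isopropyl in place of chloro, as in compound 2, remains open, as does the effect of an amine or a carboxylic acid at this position.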